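Changing one group on the sulfur of compound 1

The source may report more compounds than this note shows. Statements on the series, on what has been measured and on what is new or still open speak of the compounds shown alone.

Measured in a functional assay on HCT-116 cells (Homo sapiens) for antiproliferative activity, read by MTT assay, with a stated time of 48 h; a higher number here means a weaker inhibitor, a lower number a stronger inhibitor:
Compound 1 `COc1ccc2nc(SCC(=O)N(Cc3ccc(OC)c(O)c3)c3cc(OC)c(OC)c(OC)c3)sc2c1`: 352 nM
Compound 2 `COc1cc(N(Cc2ccc(F)cc2)C(=O)CSc2nc3ccccc3s2)cc(OC)c1OC`: 59800 nM

Of these two numbers, compound 1 holds the lower, at 352 nM, while compound 2 stands far higher at 59800 nM, a gap well beyond the scatter. These two compounds differ in more than one place, so their gap cannot be read as the result of any single change. Compound 3 `COc1ccc(CN(C(=O)CSc2nc3cc(Br)ccc3s2)c2cc(OC)c(OC)c(OC)c2)cc1O` differs from compound 1 in one place only: a group of 10 heavy atoms (7 carbon, 1 nitrogen, 1 sulfur, 1 bromine; one five-membered aromatic ring with 2 hetero atoms, one six-membered aromatic ring of carbon only) in place of a group of 11 heavy atoms (8 carbon, 1 nitrogen, 1 oxygen, 1 sulfur; one five-membered aromatic ring with 2 hetero atoms, one six-membered aromatic ring of carbon only), on a sulfur. The 6-methoxy-1,3-benzothiazol-2-yl group leaves, and the group that enters holds 1 bromine. The change sits on a sulfur whose other neighbours are: saturated chain carbon. Within the data shown here, no measured step covers this place, so the expectation is loose and takes compound 1 at 352 nM as its starting point. The estimated step is a 2.3-fold higher number from compound 1 to compound 3 (0.36 log units; beyond the scatter), a modest move towards a higher number in this assay that may not clear the scatter. The estimate for compound 3 is 800 nM, with an expected range from 150 nM to 4000 nM.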

Compound 3, half-maximal inhibitory concentration: 3380 nM
The estimate for compound 3 lay 4.2-fold (0.63 log units) below the measured number, and the stated range covers the measured number.
By their numbers in this assay, from the lowest: compound 1; then compound 3; then compound 2.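

Among these compounds, this is the first step that can be read at this place in this assay. With everything else in compound 1 held fixed, putting the group that holds 1 bromine on the sulfur in place of the 6-methoxy-1,3-benzothiazol-2-yl group gives a 9.6-fold higher number from compound 1 to compound 3 (0.98 log units; beyond the scatter), so the number in this assay does depend on what this sulfur carries, and the exchange of these two groups moves it towards weaker inhibition. Nothing available on these compounds bears on the cause of this step.

On these data alone, a single step cannot separate the departure of the methoxy from the arrival of the bromine, so it remains open which of the two accounts for the higher number, or whether both contribute. As far as these compounds go, it also remains open how the same group on the sulfur would read with a chlorine, a hydroxyl or an amine in place of the methoxy or the bromine, and whether any such group would match or improve on the number of compound 1.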